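Halogen swap on the aryl ketone of a pyrazole chalcone

The compounds below may be only part of what the source reports. "The series", "measured", "known", "first", "only" and "open" are said of these compounds alone.

Compound 2 `COc1cc(-c2cc(/C=C/C(=O)c3ccc(Cl)c(Cl)c3)[nH]n2)cc(OC)c1OC` gives -25% in a functional assay on A498 cells (Homo sapiens) for cytotoxicity, read by sulforhodamine B assay, with a stated time of 48 h, tested at 100 uM (on this read-out higher numbers stand for a weaker effect at the one concentration tested and lower numbers for a stronger effect), the higher of the two numbers recorded, with compound 1 `COc1ccc(-c2cc(/C=C/C(=O)c3ccc(N)cc3)[nH]n2)cc1` giving -96% in this assay, a gap that lies beyond the usual scatter. Compound 3 `COc1cc(-c2cc(/C=C/C(=O)c3ccc(F)c(F)c3)[nH]n2)cc(OC)c1OC` differs from compound 2 in one place (3,4-difluorophenyl in place of 3,4-dichlorophenyl on a carbonyl carbon). Within the data shown here, no measured pair shows this kind of change, so the step is expected to be small, if any, in either direction. Compound 3 is therefore estimated to give -15% in this assay, within a range from -50% to 10%, which corresponds to an expected step of a number 10 percentage points higher from compound 2 to compound 3 (within the scatter).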

Compound 3, a percentage reported as activity, at one concentration (the size of the read-out at that concentration, not a potency): -40%
The estimate for compound 3 lay 25 percentage points above the measured number; the range from low to high includes it.
By their numbers in this assay, from the lowest: compound 1; then compound 3; then compound 2.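

In this assay the swap of 3,4-dichlorophenyl for 3,4-difluorophenyl gives a number 15 percentage points lower from compound 2 to compound 3 (beyond the scatter), so the halogens on this aryl ketone change the effect at the one concentration tested, with the fluorinated compound 3 acting more strongly. Among these compounds, the step is modest, but it is the first comparison that isolates this position, as the two earlier compounds differ in more than one place. Nothing available explains the difference. From the compounds shown here alone, it remains open whether 3,4-dibromophenyl or unsubstituted phenyl on this carbonyl carbon would extend the trend or reverse it.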